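Trifluoromethoxy in Place of Methyl: an Antiproliferative Forecast

The compounds below may be only part of what the source reports. "The series", "measured", "known", "first", "only" and "open" are said of these compounds alone.

Measured compounds:
compound 1, `Cc1nn(C)c(Oc2ccc(Cl)cc2)c1/C=N\OCc1c(Cl)c(-c2ccc(F)cc2)nn1C`, 7970 nM
compound 2, `Cc1ccc(Oc2c(/C=N\OCc3c(Cl)c(-c4ccc(F)cc4)nn3C)c(C)nn2C)cc1`, 5230 nM

In a functional assay on SMMC-7721 cells (Homo sapiens) for antiproliferative activity, read by MTT assay, with a stated time of 72 h (on this read-out lower numbers stand for stronger inhibition and higher numbers for weaker inhibition), compound 2 gives 5230 nM, the lowest of the two numbers; its nearest neighbour is compound 1 at 7970 nM, and the two sit within the scatter of each other. For the measured compounds named here, the single measured step, a 1.5-fold lower number from compound 1 to compound 2 (0.18 log units; within the scatter), swaps a chloro for a methyl on an aromatic carbon and stays within the scatter.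

Compound 3, `Cc1nn(C)c(Oc2ccc(OC(F)(F)F)cc2)c1/C=N\OCc1c(Cl)c(-c2ccc(F)cc2)nn1C`, has not yet been tested. It differs from compound 2 as follows: trifluoromethoxy in place of methyl on an aromatic carbon. Going by the values given here, no measured step addresses a trifluoromethoxy group anywhere, so the one step that exists, a 1.5-fold lower number from compound 1 to compound 2 (0.18 log units; within the scatter), bears on the new change only in showing that exchanging the group at this place shifted the number very little. Compound 3 is therefore expected to stay close to compound 2, with a 1.0-fold lower number from compound 2 to compound 3 (0.02 log units; within the scatter), and an estimated value of 5000 nM, lying between 2000 nM and 13000 nM.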

Compound 3, half-maximal inhibitory concentration: 5210 nM
For compound 3 the middle estimate is 1.0-fold (0.02 log units) below the measured one; measured number inside the range.
By their numbers in this assay, from the lowest: compounds 3, 2 and 1 (each within the scatter of the next).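

In this assay, the trifluoromethoxy group brings 5 heavy atoms and 1 hydrogen-bond acceptor in place of the single carbon of methyl, yet the step stays within the scatter (a 1.0-fold lower number from compound 2 to compound 3 (0.00 log units; within the scatter)). The exchange for chloro also stays within the scatter (a 1.5-fold lower number from compound 1 to compound 3 (0.18 log units; within the scatter)), so three groups of differing size at this place, para to a large group, now give numbers that cannot be told apart. Nothing available accounts for this flat response.

As far as these compounds go, whether an amine, a carboxylic acid or a longer chain at this place would give a number beyond the scatter remains open. The compounds shown speak to this one place only, so what the rest of the shared core contributes is also unresolved.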